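Two hydroxyphenyl pyridines and the step that separates them

The source may report more compounds than this note shows. Statements on the series, on what has been measured and on what is new or still open speak of the compounds shown alone.

Measured compounds:
Compound 1, `Oc1ccccc1-c1cc(-c2cccs2)cc(-c2ccccc2O)n1`: 77.2%
Compound 2, `Oc1cccc(-c2cc(-c3cccs3)cc(-c3ccccc3O)n2)c1`: 83.2%
Compound 3, `Oc1cccc(-c2cc(-c3ccco3)cc(-c3ccccc3O)n2)c1`: 90.1%

The three compounds were tested in an assay on isolated protein for inhibition of DNA topoisomerase 1 (Homo sapiens), with a stated time of 30 min, tested at 100 uM; on this read-out lower numbers stand for a weaker effect and higher numbers for a stronger effect at the one concentration tested. Compound 1 gives 77.2%, compound 2 gives 83.2% and compound 3 gives 90.1%. Compound 1 and compound 2 differ in one place: 3-hydroxyphenyl in place of 2-hydroxyphenyl on an aromatic carbon. This gives a number 6 percentage points higher from compound 1 to compound 2 (within the scatter). Compound 2 and compound 3 also differ in one place, and that gives a number 6.9 percentage points higher from compound 2 to compound 3 (within the scatter). The difference between the core of compound 1 and the core of compound 3 is not broken down here; their two values stand apart by more than the usual scatter.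

Compound 4, `Oc1cccc(-c2cc(-c3ccco3)cc(-c3cccc(O)c3)n2)c1`, has not yet been measured in this assay. It stands to compound 3 as compound 2 stands to compound 1: 3-hydroxyphenyl in place of 2-hydroxyphenyl on an aromatic carbon. The two surroundings are not identical, since in compound 3 the place is meta to a 3-hydroxyphenyl group and to a furan-2-yl group, whereas in compound 1 it is meta to a 2-hydroxyphenyl group and to a thiophen-2-yl group, so this is the same kind of change rather than the same change. Because the earlier change gave a number 6 percentage points higher from compound 1 to compound 2 (within the scatter), a step of similar size is expected here, and compound 4 is estimated to show a number 2.9 percentage points higher from compound 3 to compound 4 (within the scatter) in this assay. Compound 4 is therefore expected to give about 93%, between 85% and 99%.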

Compound 4, a percentage reported as inhibition, at one concentration (the size of the read-out at that concentration, not a potency): 97.8%
For compound 4 the middle estimate is 4.8 percentage points below the measured one; the measured number falls inside the stated range.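

In this assay, 3-hydroxyphenyl in place of 2-hydroxyphenyl on the core of compound 3 gives a number 7.7 percentage points higher from compound 3 to compound 4 (within the scatter), and the steps for this change on the two cores do not differ beyond what repeated measurements would allow: the same change on two cores in this assay, a number 6 percentage points higher (within the scatter) from compound 1 to compound 2 and a number 7.7 percentage points higher (within the scatter) from compound 3 to compound 4, 1.7 percentage points apart, within the scatter of two such steps

Within these four compounds, then, the change carries from one core to the other with no detectable difference in the size of the step, even though the two cores differ in the furan-2-yl or thiophen-2-yl group and in the hydroxyphenyl group that stays in place. It does not show that the change itself strengthens the effect, since each step taken alone lies within the scatter, and a percentage at a single concentration is no measure of potency, so the agreement between two small steps on two closely related cores says little about how the change would behave on any other core.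

The compounds shown leave open whether a group other than hydroxyl on the phenyl rings, such as an amine, a methoxy group or a carboxylic acid, would fit the same picture. They also leave open whether the step from thiophen-2-yl to furan-2-yl, seen on one core only, would carry over to the core of compound 4.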